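This account rests on a few compounds, and the source may have more. Where it says the series, first, only, none or still open, it means among the compounds named here.

Measured compounds:
compound 1 `COc1cc(OC)c(OC)cc1/C=C/C(=O)c1ccc(O)cc1O` — 2.76 ug/mL
compound 2 `COc1cc(OC)c(OC)cc1/C=C/C(=O)c1cccc([N+](=O)[O-])c1` — 2.35 ug/mL

The account concerns two chalcones that share a trimethoxyphenyl core and differ only in the ring on the carbonyl carbon. In a functional assay, read by Griess assay, with a stated time of 2.5 h (a higher number here means a weaker inhibitor, a lower number a stronger inhibitor), compound 1 gives 2.76 ug/mL, the higher of the two numbers recorded. Compound 2 gives 2.35 ug/mL in this assay, and its gap to compound 1 lies within the scatter, so the two cannot be placed in order on these numbers alone.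

The next compound, compound 3 `COc1cc(OC)c(OC)cc1/C=C/C(=O)c1ccc(Br)cc1`, keeps the core of compound 1 and changes the ring on the carbonyl carbon: 4-bromophenyl in place of 2,4-dihydroxyphenyl on a carbonyl carbon. The 2,4-dihydroxyphenyl ring that leaves carries both hydrogen-bond donors and both hydrogen-bond acceptors of that part of the molecule; the 4-bromophenyl ring that enters carries none. Among the compounds with values here, no step between measured compounds speaks to such an exchange, and compound 2, with a ring bearing neither hydroxyl group, sits within the scatter of compound 1.

On that basis compound 3 is expected to stay close to compound 1 in this assay, with a step of a 1.3-fold higher number from compound 1 to compound 3 (0.10 log units; within the scatter) that is small and, if anything, toward a slightly higher number. Compound 3 is estimated at 3.5 ug/mL in this assay, with a range from 1.4 ug/mL to 9 ug/mL.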

Compound 3, half-maximal inhibitory concentration: 2.22 ug/mL
Beside the measured number, compound 3's estimate is 1.6-fold (0.20 log units) above it; the measured number falls inside the stated range.
By their numbers in this assay, from the lowest: compounds 3, 2 and 1 (each within the scatter of the next).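

In this assay, within the data shown here, putting 4-bromophenyl in place of 2,4-dihydroxyphenyl on a carbonyl carbon gives a 1.2-fold lower number from compound 1 to compound 3 (0.09 log units; within the scatter), the first step at this position that can be read as a single change. It shows that, in this pair, the hydrogen-bond donors and acceptors counted on the 2,4-dihydroxyphenyl ring can be exchanged for a ring with none, and for a bromine atom, without a step beyond the scatter. No measurement bears on why the step is this small, so the result remains an observation without an explanation.

All three compounds lie within the scatter of one another, so it remains open whether any group on the carbonyl carbon can move the number in this assay beyond the scatter, and the shared core stays the same throughout those shown. Going by these compounds, how a phenyl ring carrying an amine or a carboxylic acid would read, or how a longer chain in place of the ring would read, also stays open.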